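Replacing 3-nitrophenyl with 2-methylphenyl on the imine carbon

This account rests on a few compounds, and the source may have more. Where it says the series, first, only, none or still open, it means among the compounds named here.

Three compounds have been measured in a functional assay on cells (Homo sapiens) for cytotoxicity, read by MTT assay, with a stated time of 24 h; a lower number here means a stronger inhibitor, a higher number a weaker inhibitor:

compound 1, `CCCCCCCCCCCCCCNC(=O)[C@H](CO)/N=C/c1ccccc1OC`, 12500 nM
compound 2, `CCCCCCCCCCCCCCNC(=O)[C@H](CO)/N=C/c1cccc([N+](=O)[O-])c1`, 104000 nM
compound 3, `CCCCCCCCCCCCCCNC(=O)[C@H](CO)NCc1ccccc1[N+](=O)[O-]`, 29400 nM

Compound 2 shows the highest number of the three, so it is the weakest inhibitor here; compound 3 is nearer to it and compound 1 is furthest away. The unmeasured compound 4, `CCCCCCCCCCCCCCNC(=O)[C@H](CO)/N=C/c1ccccc1C`, differs from compound 2 in one place: 2-methylphenyl in place of 3-nitrophenyl on a carbon with a double bond to nitrogen. Among the compounds with values here, only one measured step bears on this change, an 8.3-fold higher number from compound 1 to compound 2 (0.92 log units; beyond the scatter), in which a 2-methoxyphenyl gave way to the 3-nitrophenyl. Compound 4 carries a small substituent in the same position as compound 1, so the step from compound 2 to compound 4 is expected to reverse that rise: a 6.9-fold lower number from compound 2 to compound 4 (0.84 log units; beyond the scatter). Compound 4 is therefore estimated at 15000 nM, within a range of 5000 nM to 45000 nM.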

Compound 4, half-maximal inhibitory concentration: 87700 nM
Estimate against measurement, compound 4: 5.8-fold (0.77 log units) below, outside the stated range (above it).
By their numbers in this assay, from the lowest: compound 1; then compound 3; then compounds 4 and 2 (each within the scatter of the next).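

In this assay, 2-methylphenyl and 3-nitrophenyl on a carbon with a double bond to nitrogen cannot be told apart (a 1.2-fold lower number from compound 2 to compound 4 (0.07 log units; within the scatter)). Methyl in place of methoxy on an aromatic carbon, by contrast, gives a clear rise (a 7.0-fold higher number from compound 1 to compound 4 (0.85 log units; beyond the scatter)), so among these compounds the lower number of compound 1 goes with its methoxy group, and a small group as such is not enough. No measurement here explains this difference.

On these data alone, whether an ethoxy group, a hydroxyl group or an amine on that aromatic carbon would match methoxy remains open.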